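Working notes: methyl step from compound 1 to compound 3

A few compounds are considered here, and "the series" means these few. Any claim that something is new, unique, unknown or untested is made for them only; others in the source may bear on it.

Measured so far:
compound 1 `O=C(NC(=S)Nc1ccc(F)cc1)c1cn(-c2ccccc2)nc1-c1ccccc1`: 3500 nM
compound 2 `O=C(NC(=S)Nc1ccc(Cl)cc1)c1cn(-c2ccccc2)nc1-c1ccccc1`: 3200 nM

Both numbers come from a functional assay on A549 cells (Homo sapiens) for inhibition, read by CCK-8 assay, with a stated time of 48 h; on this read-out lower numbers stand for stronger inhibition and higher numbers for weaker inhibition. Going by the values given here, compound 1 stands with the highest of the two numbers; its nearest neighbour is compound 2, and the single measured step, chloro in place of fluoro on an aromatic carbon, reads a 1.1-fold lower number from compound 1 to compound 2 (0.04 log units; within the scatter), which is within the scatter. No order between compound 1 and compound 2 can be read from that.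

The next compound, compound 3 `Cc1ccc(-c2nn(-c3ccccc3)cc2C(=O)NC(=S)Nc2ccc(F)cc2)cc1`, differs from compound 1 by methyl in place of hydrogen on an aromatic carbon. Among the compounds with values here, none of the measured steps touches this position: the only comparison available concerns the halogen on the other aromatic ring, and it was within the scatter. There is thus nothing to support a step in either direction beyond the scatter, and the expectation is that compound 3 sits close to compound 1, as no change at the digits printed from compound 1 to compound 3 (within the scatter) in this assay. Compound 3 is therefore estimated at 3500 nM, with a range from 1500 nM to 8000 nM, the width reflecting the absence of any step that informs this change.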

Compound 3, half-maximal inhibitory concentration: 3420 nM
Compound 3: the middle estimate sits 1.0-fold (0.01 log units) above what was measured, within the range that was stated.
By their numbers in this assay, from the lowest: compounds 2, 3 and 1 (each within the scatter of the next).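

In this assay, the change from phenyl to 4-methylphenyl reads a 1.0-fold lower number from compound 1 to compound 3 (0.01 log units; within the scatter) and so gives no difference that can be told from the scatter. Going by these compounds alone, the earlier step spoke only to the halogen on the other aromatic ring, whereas this one is the first reading on a different ring of the series: at this carbon, para to a large group, methyl in place of hydrogen gives no measurable separation from compound 1 on this read-out. Nothing measured alongside these numbers offers an explanation for this result.

Still open, going by these compounds, is whether a different group at this place, such as methoxy, an amine, a carboxylic acid or a longer alkyl chain, would give a step beyond the scatter, or whether the position stays as flat with those groups as it does with methyl. Also open, on these data alone, is whether methyl reads the same with chloro in place of fluoro on the other ring, as in compound 2, given that this step stands only on the fluoro compounds.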